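The source may report more compounds than this note shows. Statements on the series, on what has been measured and on what is new or still open speak of the compounds shown alone.

Three compounds were measured in an assay on isolated protein for inhibition of leukotriene B4 receptor 1 (Homo sapiens), tested at 10 uM; on this read-out higher numbers stand for more inhibition at the one concentration tested (going by the name of the read-out) and lower numbers for less inhibition:

Compound 1, `COCc1cc(C(C)=O)c(O)cc1OCCCCCCC#N`, gives 47%.
Compound 2, `C=CCc1cc(C(C)=O)c(O)cc1OCCCCCCCCC#N`, gives 86%.
Compound 3, `CCc1cc(C(C)=O)c(O)cc1OCCCCCCC(C)(C)C#N`, gives 65%.

Among these three, compound 2 stands highest. Its nearest neighbour on the numbers is compound 3, whose value lies lower by a margin beyond the usual scatter; furthest away is compound 1, lower still and also beyond the scatter. Going by the values given here, none of the three pairs differs in only one place, so no single step between measured compounds can be read off, and what separates compound 2 from the other two is a mixture of changes on the core and on the chain.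

Compound 4, `C=CCc1cc(C(C)=O)c(O)cc1OCCCCCC(C)(C)O`, has not yet been measured in this assay. It differs from compound 2 in one place: 1-hydroxy-1-methylethyl in place of 3-cyanopropyl on a saturated chain carbon, five bonds along the chain from an oxygen on an aromatic ring. The change sits on a saturated chain carbon, five bonds along the chain from an oxygen on an aromatic ring, and exchanges a nitrile-bearing chain end for a shorter one carrying a hydroxyl.

Among the compounds with values here, no measured pair shows this exchange, so the expectation rests on the value of compound 2 alone. The step of a number 26 percentage points lower from compound 2 to compound 4 (beyond the scatter) is expected to be a moderate fall, somewhat beyond the scatter. Compound 4 is therefore estimated to give 60%, within a range from 30% to 85%.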

Compound 4, a percentage reported as inhibition, at one concentration (the size of the read-out at that concentration, not a potency): 98%
Estimate against measurement, compound 4: 38 percentage points below; the whole stated range lies below it.
By their numbers in this assay, from the lowest: compound 1; then compound 3; then compound 2; then compound 4.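

Going by these compounds alone, the exchange of 3-cyanopropyl for 1-hydroxy-1-methylethyl provides the only single-place comparison in this set, and in this assay the result is a number 12 percentage points higher from compound 2 to compound 4 (beyond the scatter). It shows that, on a saturated chain carbon, five bonds along the chain from an oxygen on an aromatic ring, a nitrile at the chain end is not needed for strong inhibition at the one concentration tested, since compound 4 carries a hydroxyl there instead and gives 98% in this read-out. Nothing shown here bears on why the number rises with this exchange.

Within the data shown here, the single pair cannot separate the effect of removing the nitrile from that of adding the hydroxyl, nor show whether a primary alcohol, an amine or a carboxylic acid at the chain end would give a similar number. It also leaves open whether the same exchange would raise the number on the cores of compound 1 and compound 3, and, as each figure comes from one concentration, how compound 2 and compound 4 compare in potency.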